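This account rests on a few compounds, and the source may have more. Where it says the series, first, only, none or still open, it means among the compounds named here.

Among the measured compounds shown here, compound 2 `CC(=O)N1CC(NC(=O)c2ccncc2Nc2cc(-c3ccc4ccn(C)c4c3)c3nccnc3c2)C1` has only one measured neighbour to be compared with. In a physicochemical assay for solubility, read by spectrophotometry, measured as kinetic solubility, at pH 8, tested at 500 uM (a lower number here means a less soluble compound, a higher number a more soluble compound), compound 2 gives 244 ug/mL, while compound 1 `CN1CC(NC(=O)c2ccncc2Nc2cc(-c3ccc4ccn(C)c4c3)c3nccnc3c2)CCC1=O` gives 253 ug/mL. These two values lie within the scatter of each other, so neither compound can be said to stand apart.

The next compound, compound 3 `CC(=O)N1CCC(NC(=O)c2ccncc2Nc2cc(-c3ccc4ccn(C)c4c3)c3nccnc3c2)C1`, keeps the shared core and has 1-acetylpyrrolidin-3-yl in place of 1-acetylazetidin-3-yl on an amide-type nitrogen.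

For the measured compounds named here, only one measured step bears on this change. It also swaps the group on an amide-type nitrogen, with 1-acetylazetidin-3-yl taking the place of 1-methyl-6-oxopiperidin-3-yl, and it amounts to a 1.0-fold lower number from compound 1 to compound 2 (0.02 log units; within the scatter). That step is within the scatter, although a single pair is thin evidence and says little about this exact exchange.

On that basis, no step beyond the scatter is expected, and the estimated change is a 1.0-fold lower number from compound 2 to compound 3 (0.01 log units; within the scatter). Compound 3 is expected to read about 240 ug/mL, with an estimated range from 130 ug/mL to 290 ug/mL.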

Compound 3, solubility: 253 ug/mL
Beside the measured number, compound 3's estimate is 1.1-fold (0.02 log units) below it; low and high end bracket the measured number.
By their numbers in this assay, from the lowest: compounds 2, 1 and 3 (each within the scatter of the next).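

In this assay, exchanging the four-membered ring of 1-acetylazetidin-3-yl for the five-membered ring of 1-acetylpyrrolidin-3-yl on the amide-type nitrogen gives a 1.0-fold higher number from compound 2 to compound 3 (0.02 log units; within the scatter), so this change of ring size does not separate the two compounds. Among the compounds shown here, the other new step, no change at the digits printed from compound 1 to compound 3 (within the scatter), shows that 1-acetylpyrrolidin-3-yl and 1-methyl-6-oxopiperidin-3-yl cannot be told apart either, which means that all three groups at this position now read alike within the scatter, where the earlier compounds offered only a single pair. No measurement is available that could explain why these groups read alike.

Going by these compounds, all three groups are rings that carry a carbonyl, so it remains open whether a group of a different kind on the same nitrogen, such as a piperidine with a free amine, a carboxylic acid or a longer open chain, would move the number beyond the scatter. On these data alone, it is also open whether these groups would read alike on a core other than the shared one.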